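The source may hold more compounds than are shown below. What is called first, only, known or untested is meant among the compounds shown, and "the series" means these compounds.

Three compounds have been measured in a functional assay on NCI-H460 cells (Homo sapiens) for cytotoxicity, read by MTT assay, with a stated time of 72 h; a higher number here means a weaker inhibitor, a lower number a stronger inhibitor:

Compound 1 `CN(C)CCn1cnnc1-c1cc(Oc2ccc(NC(=O)N/N=C/c3cccc(Br)c3)cc2F)ccn1`: 520 nM
Compound 2 `CN(C)CCn1cnnc1-c1cc(Oc2ccc(NC(=O)N/N=C/c3ccc(O)c(O)c3)cc2F)ccn1`: 1930 nM
Compound 3 `CN(C)CCn1cnnc1-c1cc(Oc2ccc(NC(=O)N/N=C/c3ccc(F)cc3)cc2F)ccn1`: 1980 nM

All three share one core and differ only in the aryl group attached to the carbon that carries a double bond to nitrogen. Compound 3 shows the highest number of the three. Its gap to compound 2 is tiny, a 1.0-fold higher number from compound 2 to compound 3 (0.01 log units; within the scatter), so the two cannot be told apart. Its gap to compound 1 is larger, a 3.8-fold higher number from compound 1 to compound 3 (0.58 log units; beyond the scatter), and compound 1 also stands apart from compound 2 by a 3.7-fold higher number from compound 1 to compound 2 (0.57 log units; beyond the scatter).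

Compound 4 `CN(C)CCn1cnnc1-c1cc(Oc2ccc(NC(=O)N/N=C/c3ccccc3)cc2F)ccn1` is the next step from compound 3. The change is small: hydrogen in place of fluoro on an aromatic carbon. Among the compounds with values here, none of the measured steps makes this exact change; both steps from compound 1 replace the whole aryl group, so they give only a rough sense of how far such a swap can move the number. With no closer guide, the expectation is a step in this assay of about a 1.3-fold lower number from compound 3 to compound 4 (0.12 log units; within the scatter), not beyond the scatter, if anything toward a lower number. Compound 4 is therefore expected to give roughly 1500 nM, with a likely range from 600 nM to 4000 nM.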

Compound 4, half-maximal inhibitory concentration: 1780 nM
Compound 4: the middle estimate sits 1.2-fold (0.07 log units) below what was measured; low and high end bracket the measured number.
By their numbers in this assay, from the lowest: compound 1; then compounds 4, 2 and 3 (each within the scatter of the next).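

In this assay, the plain phenyl of compound 4 cannot be told apart from the 4-fluorophenyl (a 1.1-fold lower number from compound 3 to compound 4 (0.05 log units; within the scatter)), so the fluoro on this ring, at the place para to a large group, makes no readable difference here. The phenyl also matches the 3,4-dihydroxyphenyl (a 1.1-fold lower number from compound 2 to compound 4 (0.04 log units; within the scatter)), which places three different aryl groups within the scatter of one another, even though one carries no substituent, one a single fluoro and one two hydroxyl groups. With the unsubstituted ring now available as a baseline, compound 1 is the only one of the four that stands apart (a 3.4-fold higher number from compound 1 to compound 4 (0.53 log units; beyond the scatter)), and that single step is hydrogen in place of bromo, so the gap can be tied to the bromo substituent rather than to a change of the whole aryl group.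

Nothing measured here explains why the bromo compound stands apart. On these data alone, it remains open whether the gap is specific to bromo, since a chloro, a methyl or an amine in its place on the phenyl ring would be needed to show whether other groups there give a similar number.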